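Taking the phenyl off compound 2: working notes

The source may report more compounds than this note shows. Statements on the series, on what has been measured and on what is new or still open speak of the compounds shown alone.

Measured so far in a functional assay on HBL-100 cells (Homo sapiens) for antiproliferative activity, read by sulforhodamine B assay, with a stated time of 48 h; a higher number here means a weaker inhibitor of growth, a lower number a stronger inhibitor of growth 
- compound 1 `CCCCCC(C#CC(=O)OC)O/C=C/C(=O)OC` gives 1900 nM 
- compound 2 `COC(=O)C#CC(O/C=C/C(=O)OC)C(C)c1ccccc1` gives 490 nM 

Of the two, compound 2 has the lower number (490 nM) and compound 1 the higher (1900 nM), a gap beyond the usual scatter. On these numbers, compound 2 is the stronger inhibitor of growth.

Compound 3 `CCC(C#CC(=O)OC)O/C=C/C(=O)OC` has not yet been measured. Its change from compound 2 (hydrogen in place of phenyl on a saturated chain carbon bound to two saturated chain carbons) is hydrogen in place of phenyl on a saturated chain carbon bound to two saturated chain carbons.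

For the measured compounds named here, no measured pair isolates this change, so any expectation in this assay remains loose. Going by the values given here, the only guide is compound 1, which also has no phenyl and gives 1900 nM in that test. A rise in the number beyond the scatter is expected, of a size like the gap just noted or a little larger. The estimated shift is a 5.1-fold higher number from compound 2 to compound 3 (0.71 log units; beyond the scatter) and carries wide uncertainty. The estimated value for compound 3 is 2500 nM (expected range 800 nM to 8000 nM).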

Compound 3, concentration for 50% growth inhibition: 320 nM
Compound 3: the middle estimate sits 7.8-fold (0.89 log units) above what was measured, outside the stated range (below it).
By their numbers in this assay, from the lowest: compounds 3 and 2 (each within the scatter of the next); then compound 1.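

Working notes on the series: in this assay, hydrogen in place of phenyl on a saturated chain carbon bound to two saturated chain carbons gives a 1.5-fold lower number from compound 2 to compound 3 (0.19 log units; within the scatter) and so shows that, in this pair, the phenyl at this position is not required for the growth inhibition seen with compound 2. Hydrogen in place of propyl on a saturated chain carbon, three bonds along the chain from an oxygen on an unsaturated carbon and a triple-bonded carbon, gives a 5.9-fold lower number from compound 1 to compound 3 (0.77 log units; beyond the scatter) and shows that, among the compounds without a phenyl, the chain at this place does register in the read-out. Nothing on hand bears on why either step has the size it has.

Still open, going by these compounds, is how a hydroxyl, an amine or a carboxylic acid would read at this saturated chain carbon, and whether a butyl chain would sit nearer compound 3 or compound 1. Also open, on these data alone, is whether these two steps keep their size in cell lines other than this one.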